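Piperazinyl Amide in a Cathepsin S Nitrile Series

The source may hold more compounds than are shown below. What is called first, only, known or untested is meant among the compounds shown, and "the series" means these compounds.

Three compounds share one core and differ only in the ring on the amide carbonyl. In an assay on isolated protein for inhibition of cathepsin S (Homo sapiens), read by fluorescence, with a stated time of 20 min (a lower number here means a stronger inhibitor, a higher number a weaker inhibitor), compound 1 `N#CC1(NC(=O)[C@@H]2C[C@@H](S(=O)(=O)c3ccccc3)C[C@H]2C(=O)N2CCOCC2)CC1` gives 0.7 nM, compound 2 `C[C@@H]1CN(C(=O)[C@@H]2C[C@H](S(=O)(=O)c3ccccc3)C[C@H]2C(=O)NC2(C#N)CC2)C[C@H](C)O1` gives 0.4 nM, and compound 3 `CC1CCN(C(=O)[C@@H]2C[C@H](S(=O)(=O)c3ccccc3)C[C@H]2C(=O)NC2(C#N)CC2)CC1` gives 0.5 nM. Compound 3 holds the second highest of these three numbers, with compound 2 nearest and compound 1 furthest, both within the scatter. Compound 4 `N#CC1(NC(=O)[C@@H]2C[C@@H](S(=O)(=O)c3ccccc3)C[C@H]2C(=O)N2CCNCC2)CC1` differs from compound 3 by piperazin-1-yl in place of 4-methylpiperidin-1-yl on a carbonyl carbon. Within the data shown here, the steps that bear on this exchange of the amide ring are a 1.4-fold lower number from compound 1 to compound 3 (0.15 log units; within the scatter), a 1.3-fold higher number from compound 2 to compound 3 (0.10 log units; within the scatter) and a 1.8-fold lower number from compound 1 to compound 2 (0.24 log units; within the scatter), none of them beyond the scatter. A step of like size is therefore expected in this assay, namely a 1.2-fold higher number from compound 3 to compound 4 (0.08 log units; within the scatter). Compound 4 is estimated at 0.6 nM, between 0.25 nM and 1.5 nM.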

Compound 4, half-maximal inhibitory concentration: 11 nM
Compound 4: middle estimate off by 18-fold (1.26 log units), on the low side; the measured number lies above the stated range.
By their numbers in this assay, from the lowest: compounds 2, 3 and 1 (each within the scatter of the next); then compound 4.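

In this assay, the ring on this carbonyl carbon proves not to be freely exchangeable: piperazin-1-yl gives a 22-fold higher number from compound 3 to compound 4 (1.34 log units; beyond the scatter), a 28-fold higher number from compound 2 to compound 4 (1.44 log units; beyond the scatter) and a 16-fold higher number from compound 1 to compound 4 (1.20 log units; beyond the scatter), although the three earlier rings stayed within the scatter of one another. Unlike 4-methylpiperidin-1-yl, the entering ring carries a hydrogen-bond donor, but that difference is only counted from the structures, not tied to the loss. No measurement given here accounts for this step. On these data alone, whether 4-methylpiperazin-1-yl or 4-acetylpiperazin-1-yl on the same carbonyl carbon would track compound 4 or the other three remains open.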